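The source may report more compounds than this note shows. Statements on the series, on what has been measured and on what is new or still open speak of the compounds shown alone.

Working notes on the series.

Three compounds in this set have numbers in an in vitro ADME assay on microsomes from liver (Homo sapiens) for metabolic stability, read by LC-MS; a lower number here means that the compound disappears faster, a higher number that the compound lasts longer. Within the data shown here, compound 1 `CCCCc1ccc(NC(=O)N2CCCN(C(=O)CCC3CCCC3)CC2)cc1` gives 0.0833 h, and compound 2 `CCc1ccc(NC(=O)N2CCCN(C(=O)CCC3CCCC3)CC2)cc1` gives 0.0833 h; the only single-point step measured so far, no change at the digits printed from compound 1 to compound 2 (within the scatter), leaves the number where it was. Compound 3 `CC(C)(C)c1ccc(NC(=O)N2CCCN(C(=O)CC3CCCC3)CC2)cc1` gives 0.05 h; its values against compound 1 and against compound 2 sit within the scatter of one another, so the three numbers describe one narrow band rather than a spread.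

Compound 4 `CN(C)c1ccc(C(=O)N2CCCN(C(=O)Nc3ccc(C(C)(C)C)cc3)CC2)cc1` differs from compound 3 in one place: 4-(dimethylamino)phenyl in place of cyclopentylmethyl on a carbonyl carbon. Among the measured compounds shown here, no measured step touches this carbonyl carbon, so there is no step of known size to lean on for this change, and the one step measured, from compound 1 to compound 2, concerns a different position and has no bearing here. The expectation therefore rests on the band set by compound 1, compound 2 and compound 3. Compound 4 is estimated at 0.08 h in this assay, with a range from 0.03 h to 0.25 h, which means an expected step of a 1.6-fold higher number from compound 3 to compound 4 (0.20 log units; within the scatter), not beyond the scatter in either direction.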

Compound 4, half-life: 0.0667 h
For compound 4 the middle estimate is 1.2-fold (0.08 log units) above the measured one; the range from low to high includes it.
By their numbers in this assay, from the lowest: compounds 3, 4, 1 and 2 (each within the scatter of the next).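

Among these compounds, on a carbonyl carbon whose other neighbour is an amide-type nitrogen in a ring, compound 4 gives the first measured step at this position in this assay (a 1.3-fold higher number from compound 3 to compound 4 (0.13 log units; within the scatter)). The exchange replaces a five-membered non-aromatic ring of carbon only with a six-membered aromatic ring of carbon only, and adds heavy atoms and a hydrogen-bond acceptor, yet the half-life does not move beyond the scatter. No supporting measurement bears on why this step stays so small.

Going by these compounds, whether a carboxylic acid, an amine or a longer chain on this carbonyl carbon would also stay within the scatter remains open. So does whether 4-(dimethylamino)phenyl would give a step of the same size with a group other than tert-butyl on the far aromatic ring.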